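A few compounds are considered here, and "the series" means these few. Any claim that something is new, unique, unknown or untested is made for them only; others in the source may bear on it.

Measured compounds:
compound 1 `CC(C)n1cnnc1-c1cccc(NC(=O)Nc2nccc3ccccc23)n1` gives 201 nM
compound 2 `CC(C)n1cnnc1-c1cccc(NC(=O)Nc2cnc3ccccc3n2)n1` gives 4860 nM
compound 3 `C[C@H](CO)n1cnnc1-c1cccc(NC(=O)Nc2nccc3ccccc23)n1` gives 264 nM

In an assay on isolated protein for inhibition of mitogen-activated protein kinase kinase kinase 6 (Homo sapiens) (a lower number here means a stronger inhibitor, a higher number a weaker inhibitor), the three compounds fall into two groups. Compound 1 and compound 3 share a core and differ only by hydroxy in place of hydrogen on a saturated chain carbon, two bonds along the chain from an aromatic nitrogen; the step of a 1.3-fold higher number from compound 1 to compound 3 (0.12 log units; within the scatter). Compound 2 stands apart: its number is the highest of the three, and its steps to compound 3 and to compound 1 are both beyond the scatter, so it is the weakest inhibitor here. The difference between the core of compound 1 and the core of compound 2 is not broken down here.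

Compound 4 `C[C@H](CO)n1cnnc1-c1cccc(NC(=O)Nc2cnc3ccccc3n2)n1` has not been measured. It carries hydroxy in place of hydrogen on a saturated chain carbon, two bonds along the chain from an aromatic nitrogen on the core of compound 2, the same change as that from compound 1 to compound 3. Because that earlier step was a 1.3-fold higher number from compound 1 to compound 3 (0.12 log units; within the scatter), a similarly small step is expected here, so that a 1.3-fold higher number from compound 2 to compound 4 (0.11 log units; within the scatter) is the estimate. On that basis compound 4 is expected to give about 6300 nM in this assay, plausibly between 2500 nM and 16000 nM.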

Compound 4, half-maximal inhibitory concentration: > 10000 nM
Compound 4 was reported as a limit (the forecaster's own chance of this, stated with the estimate: 10%); at least 1.5-fold (0.20 log units) between middle value and limit.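

In this assay, compound 4 gives > 10000 nM, a value that is a limit of the assay and not a number. Even so, the hydroxy on the core of compound 2 can be read as a step, an at least 2.0-fold higher number from compound 2 to compound 4 (0.31 log units; beyond the scatter), so on this core the change carries a cost beyond the scatter, whereas the earlier step on the other core stayed within it. This does not show that the change acts differently on the two cores, and carrying the earlier step over from one core to the other is neither confirmed nor ruled out: the same change on two cores in this assay, a 1.3-fold higher number (0.12 log units; within the scatter) from compound 1 to compound 3 and an at least 2.0-fold higher number (0.31 log units; beyond the scatter) from compound 2 to compound 4; the limit leaves it open whether they differ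

The compounds shown leave open how far the true number of compound 4 lies from the limit, and so how large this step really is: the limit of > 10000 nM in this assay, at which 1 of the 4 values shown sits. They also leave open how an amine, a carboxylic acid or a longer chain in place of the hydroxy would read on either core.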